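Bromophenyl Position Swap on a Dimethoxy Cyclohexanone Core

The compounds below may be only part of what the source reports. "The series", "measured", "known", "first", "only" and "open" are said of these compounds alone.

Measured compounds:
compound 1, `COc1cccc(/C=C2\CCC/C(=C\c3ccccc3Br)C2=O)c1OC` — 12100 nM
compound 2, `COc1cccc(/C=C2\CCC/C(=C\c3cccc(Br)c3)C2=O)c1OC` — 8800 nM
compound 3, `COc1ccc(/C=C2\CCC/C(=C\c3ccccc3Br)C2=O)cc1OC` — 5300 nM

In a functional assay on SW-620 cells (Homo sapiens) for cytotoxicity, read by MTT assay, with a stated time of 72 h (a higher number here means a weaker inhibitor, a lower number a stronger inhibitor), compound 1 gives 12100 nM and compound 2 gives 8800 nM. The two are related by 3-bromophenyl in place of 2-bromophenyl on a double-bonded chain carbon bound to a double-bonded ring carbon, and the step is a 1.4-fold lower number from compound 1 to compound 2 (0.14 log units; within the scatter). Compound 3 differs from compound 1 in its core; the difference between the two cores is not broken down here. In this assay compound 3 gives 5300 nM, which against compound 1 lies beyond the scatter and against compound 2 lies within it.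

Compound 4, `COc1ccc(/C=C2\CCC/C(=C\c3cccc(Br)c3)C2=O)cc1OC`, has not yet been measured in this assay. It carries the same change on the core of compound 3 that turned compound 1 into compound 2, namely (3-bromophenyl in place of 2-bromophenyl on a double-bonded chain carbon bound to a double-bonded ring carbon). Since the earlier step of a 1.4-fold lower number from compound 1 to compound 2 (0.14 log units; within the scatter) was small and within the scatter, a step of similar size is expected here, resting on that single pair alone. The expected step is a 1.4-fold lower number from compound 3 to compound 4 (0.14 log units; within the scatter). Compound 4 is therefore estimated at 3800 nM, between 1800 nM and 8000 nM.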

Compound 4, half-maximal inhibitory concentration: 4200 nM
Beside the measured number, compound 4's estimate is 1.1-fold (0.04 log units) below it; the range from low to high includes it.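

In this assay, 3-bromophenyl in place of 2-bromophenyl on the second core gives a 1.3-fold lower number from compound 3 to compound 4 (0.10 log units; within the scatter) and so stays inside the usual scatter of repeated measurements. Set beside the earlier step, the change reads the same on both cores: the same change on two cores in this assay, a 1.4-fold lower number (0.14 log units; within the scatter) from compound 1 to compound 2 and a 1.3-fold lower number (0.10 log units; within the scatter) from compound 3 to compound 4, 1.1-fold (0.04 log units) apart, within the scatter of two such steps. This shows that, across these two pairs, the swap carries from one core to the other without any detectable difference in its size. It does not show that the swap itself has a real effect, since neither step stands clear of the scatter, and two small steps that agree say little about how the change would behave on any further core.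

All four compounds carry a bromophenyl group on one side and two methoxy groups on the other. The compounds shown leave open whether this agreement would hold if the bromine gave way to an amine or a carboxylic acid, or if the methoxy groups gave way to a longer chain.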